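The compounds below may be only part of what the source reports. "The series", "measured", "known", "first", "only" and "open" are said of these compounds alone.

Working notes on the series. Compound 2 `CNC(=O)CSc1nc2ccc(NC(=O)c3ccc(Cl)cc3)cc2s1` is the point of departure; in a functional assay on HepG2 cells (Homo sapiens) for cytotoxicity, read by MTT assay, with a stated time of 48 h (on this read-out higher numbers stand for weaker inhibition and lower numbers for stronger inhibition), compound 2 gives 15300 nM, the higher of the two numbers actually read, with compound 1 `COc1ccc(CNC(=O)CSc2nc3ccc(NC(=O)c4ccccc4OC)cc3s2)cc1` nearest at 2100 nM. Compound 3 `CNC(=O)CSc1nc2ccc(NC(=O)c3ccc([N+](=O)[O-])cc3)cc2s1` gives only a limit of the assay, > 100000 nM, in this assay. Going by the values given here, the one step read within a single change, an at least 6.5-fold higher number from compound 2 to compound 3 (0.81 log units; beyond the scatter), sits on the aryl amide and not on the chain amide, so it does not speak to the present change; compound 3 sits at the limit of > 100000 nM in this assay, at which 1 of the 3 values shown sits. Compound 4 `O=C(CSc1nc2ccc(NC(=O)c3ccc(Cl)cc3)cc2s1)NCc1ccccc1` differs from compound 2 by phenyl in place of hydrogen on a saturated chain carbon bound to an amide-type nitrogen. Among the compounds with values here, no measured pair isolates this change: compound 1 carries a benzyl-type amide together with a different aryl amide, and its value stands well under that of compound 2, but the two differences cannot be separated. A modest move toward a lower number is therefore expected for compound 4, a 3.1-fold lower number from compound 2 to compound 4 (0.49 log units; beyond the scatter), with wide uncertainty. Compound 4 is estimated at 5000 nM, between 1500 nM and 20000 nM.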

Compound 4, half-maximal inhibitory concentration: 25400 nM
For compound 4 the middle estimate is 5.1-fold (0.71 log units) below the measured one; measured number outside the range, above it.
By their numbers in this assay, from the lowest: compound 1; then compounds 2 and 4 (each within the scatter of the next). At a limit, above all of these: compound 3.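

On the saturated chain carbon bound to an amide-type nitrogen, the change now stands alone: in this assay, phenyl in place of hydrogen reads as a 1.7-fold higher number from compound 2 to compound 4 (0.22 log units; within the scatter), so methylcarbamoyl and benzylcarbamoyl cannot be told apart on the aryl amide of compound 2. This step therefore gives no support for crediting the benzyl-type amide with the value of compound 1, 2100 nM, and that value remains tied up with its other differences. Nothing measured here offers a cause for this result.

As far as these compounds go, how an amine, a carboxylic acid or a longer chain in place of phenyl at this place would read stays open. Also open, from the compounds shown here alone, is whether phenyl in place of hydrogen reads the same with the aryl amide of compound 1 as with that of compound 2.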